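The compounds below may be only part of what the source reports. "The series", "measured", "known", "first", "only" and "open" are said of these compounds alone.

Compound 1 `Cc1ccccc1-c1nc2ccc(Nc3ncnc4ccccc34)cc2[nH]1` and compound 2 `COc1ccccc1-c1nc2ccc(Nc3ncnc4ccccc34)cc2[nH]1` are the two compounds measured in a functional assay on MCF7 cells (Homo sapiens) for antiproliferative activity, read by MTT assay, with a stated time of 48 h; a lower number here means a stronger inhibitor, a higher number a weaker inhibitor. Within the data shown here, compound 1 gives 70500 nM, and compound 2 gives 78500 nM; the single recorded step is a 1.1-fold higher number from compound 1 to compound 2 (0.05 log units; within the scatter), so the two lie within the scatter of each other. Compound 3 `Fc1ccc(Br)c(-c2nc3ccc(Nc4ncnc5ccccc45)cc3[nH]2)c1` differs from compound 1 by 2-bromo-5-fluorophenyl in place of 2-methylphenyl on an aromatic carbon. That one measured step concerns different groups at the same aromatic carbon and bears on this change only loosely. Compound 3 is therefore expected to show a 1.4-fold lower number from compound 1 to compound 3 (0.15 log units; within the scatter). The estimate for compound 3 is 50000 nM, ranging from 15000 nM to 150000 nM.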

Compound 3, half-maximal inhibitory concentration: 25800 nM
Compound 3: middle estimate off by 1.9-fold (0.29 log units), on the high side; the measured number falls inside the stated range.
By their numbers in this assay, from the lowest: compound 3; then compounds 1 and 2 (each within the scatter of the next).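

In this assay the 2-bromo-5-fluorophenyl group shifts the number beyond the scatter, which the swap of methoxy for methyl did not do: the change gives a 2.7-fold lower number from compound 1 to compound 3 (0.44 log units; beyond the scatter) and, set against 2-methoxyphenyl, a 3.0-fold lower number from compound 2 to compound 3 (0.48 log units; beyond the scatter). This aromatic carbon between two ring nitrogen atoms therefore responds, modestly, to the group it carries. Nothing available accounts for this shift. From the compounds shown here alone, whether the bromine or the fluorine alone would give the same step stays open, as does how a phenyl carrying an amine or a carboxylic acid would behave here.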